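The compounds below may be only part of what the source reports. "The series", "measured", "known", "first", "only" and "open" are said of these compounds alone.

In a functional assay on U2OS cells (Homo sapiens) for antiproliferative activity, read by MTT assay, with a stated time of 72 h (a lower number here means a stronger inhibitor, a higher number a weaker inhibitor), compound 1 `O=C(C1=C(O)C(=O)N(CCCn2ccnc2)C1c1ccc(Br)cc1)c1ccccc1` gives "not active" (no number reported), compound 2 `NC1=C(C(=O)c2ccccc2)C(c2ccc(Br)cc2)N(CCCn2ccnc2)C1=O` gives 149000 nM, and compound 3 `O=C(C1=C(Nc2ccccc2)C(=O)N(CCCn2ccnc2)C1c1ccc(Br)cc1)c1ccccc1` gives 25700 nM. Within the data shown here, compound 3 therefore holds the lowest of the two numbers, reached through the step of a 5.8-fold lower number from compound 2 to compound 3 (0.76 log units; beyond the scatter), phenyl in place of hydrogen on an amine nitrogen, the only measured step. Compound 4 `CCOc1ccc(NC2=C(C(=O)c3ccccc3)C(c3ccc(Br)cc3)N(CCCn3ccnc3)C2=O)cc1` differs from compound 3 by ethoxy in place of hydrogen on an aromatic carbon, para to a large group, anilino to (4-ethoxyphenyl)amino. Among the measured compounds shown here, no measured step bears on a substituent of that phenyl, so the change is expected to stay within the scatter, with a slight lowering as the more likely side. For compound 4 the estimate in this assay is 20000 nM, with a range from 7000 nM to 60000 nM. The expected step is a 1.3-fold lower number from compound 3 to compound 4 (0.11 log units; within the scatter).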

Compound 4, half-maximal inhibitory concentration: 26200 nM
Compound 4: the middle estimate sits 1.3-fold (0.12 log units) below what was measured, within the range that was stated.
By their numbers in this assay, from the lowest: compounds 3 and 4 (each within the scatter of the next); then compound 2.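

Ethoxy para to a large group, on the phenyl of compound 3, leaves the number in this assay within the scatter (a 1.0-fold higher number from compound 3 to compound 4 (0.01 log units; within the scatter)). The advantage over the unsubstituted amine therefore persists with the larger 4-ethoxyphenyl group (a 5.7-fold lower number from compound 2 to compound 4 (0.75 log units; beyond the scatter)), so this position tolerates ethoxy in this assay. No measurement shown accounts for either step.

Still open, on these data alone, is whether a carboxylic acid, an amine or a longer alkoxy chain at this position would keep the number unchanged. As far as these compounds go, the effect of fluorine or methoxy at other places on that phenyl also remains open.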